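From fluoro to trifluoromethyl: compound 2 to compound 3

This account rests on a few compounds, and the source may have more. Where it says the series, first, only, none or still open, it means among the compounds named here.

In an ADME assay on HepG2 cells (Homo sapiens) for cytotoxicity, read by MTT assay, with a stated time of 72 h (on this read-out higher numbers stand for lower toxicity in this test and lower numbers for higher toxicity in this test), compound 1 (`CCN(CC)c1ccc(-c2cc(Cl)cn3c([N+](=O)[O-])c(CS(=O)(=O)c4ccccc4)nc23)cc1`) gives > 15600 nM and this is a limit of the assay. Compound 2 (`O=[N+]([O-])c1c(CS(=O)(=O)c2ccccc2)nc2c(-c3cccc(F)c3)cc(Cl)cn12`) also gives only a limit, > 12500 nM and so no exact number. Compound 3 (`O=[N+]([O-])c1c(CS(=O)(=O)c2ccccc2)nc2c(-c3cccc(C(F)(F)F)c3)cc(Cl)cn12`) has trifluoromethyl in place of fluoro on an aromatic carbon. Among the compounds with values here, the one measured step that bears on this is a step that the two limits leave unreadable from compound 1 to compound 2 and it offers no size to carry over. In this assay no change beyond the scatter is therefore expected, with an estimated at least 1.0-fold lower number from compound 2 to compound 3 (0.01 log units; that floor lies within the scatter) as the step. For compound 3 the estimated value is 12000 nM within an expected range of 5000 nM to 30000 nM as a rough guide.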

Compound 3, half-maximal cytotoxic concentration: > 12500 nM
Compound 3: a limit, no number; the forecaster's own chance of this, stated with the estimate: 75%; at least 1.0-fold (0.01 log units) between middle value and limit.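

In this assay compound 3 gives > 12500 nM, a limit and not a number, so its steps from compound 1 and compound 2 cannot be read. The compounds shown leave open whether trifluoromethyl and fluoro differ at all on this read-out.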